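Swapping an Amide for an Ether on a Fused Core

The source may hold more compounds than are shown below. What is called first, only, known or untested is meant among the compounds shown, and "the series" means these compounds.

Of the compounds shown here, two sharing one fused core have been tested in a functional assay on HEK293 cells for agonist activity at G-protein coupled receptor 39 (Homo sapiens), read by scintillation proximity assay and inositol phosphate accumulation, with a stated time of 75 min; a higher number here means that more compound is needed for the effect, a lower number that less compound is needed. Compound 1 `Cc1nn(-c2ncnc3nc[nH]c23)c2c1C(OCC(=O)c1ccc(F)cc1)CC(=O)N2` gives 973 nM in this assay. Among the measured compounds shown here, compound 2 `Cc1nn(-c2ncnc3nc[nH]c23)c2c1C(C(=O)N(C)c1ccccc1)CC(=O)N2` gives 5220 nM in this assay, the higher of the two numbers; its only neighbour is compound 1, whose number is lower by more than the usual scatter, so the gap between them is real rather than noise.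

Compound 3 `Cc1nn(-c2ncnc3nc[nH]c23)c2c1C(OCC(C)C)CC(=O)N2` has not yet been measured. It differs from compound 2 in one place: isobutoxy in place of methyl(phenyl)carbamoyl on a saturated ring carbon. For the measured compounds named here, no measured pair differs by exactly this change, so the size of the step is uncertain. Compound 1, which also carries an ether-linked chain on the same saturated ring carbon, gives 973 nM, a lower number than the amide-bearing compound 2, while the chain entering compound 3 is shorter and carries no ring. The step is expected to be a 2.6-fold lower number from compound 2 to compound 3 (0.42 log units; beyond the scatter), a modest move toward a lower number. Compound 3 is therefore expected to give 2000 nM in this assay, within a range from 500 nM to 8000 nM.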

Compound 3, half-maximal effective concentration: 111 nM
Compound 3: the middle estimate sits 18-fold (1.26 log units) above what was measured; measured number below the stated range.
By their numbers in this assay, from the lowest: compound 3; then compound 1; then compound 2.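

In this assay, the saturated ring carbon turns out to be a highly sensitive position: isobutoxy in place of methyl(phenyl)carbamoyl gives a 47-fold lower number from compound 2 to compound 3 (1.67 log units; beyond the scatter) and shows that a small chain with no ring can do far better here than the larger amide group. With the ether link kept, isopropyl in place of (4-fluorophenyl)carbonyl on the saturated chain carbon gives an 8.8-fold lower number from compound 1 to compound 3 (0.94 log units; beyond the scatter) in the same direction, so a low number at this position does not depend on an aromatic ring or a carbonyl in the chain. No measured evidence accounts for either step.

The step from compound 2 changes the linking atoms and removes the phenyl ring at once, so a group such as dimethylcarbamoyl, an amide without the ring, would be needed to tell these two changes apart. On these data alone, how far the trend toward smaller chains extends also remains open, and comparing ethoxy, a longer chain such as hexyloxy, and an amine on the same carbon would show whether isobutoxy is close to the best fit or just one point on a wider range.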